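This account rests on a few compounds, and the source may have more. Where it says the series, first, only, none or still open, it means among the compounds named here.

Measured in an ADME assay on HEK293 cells (Homo sapiens) for cytotoxicity, read by MTT assay, with a stated time of 48 h; a higher number here means a weaker inhibitor, a lower number a stronger inhibitor:
compound 1 `Cc1ccc(S(=O)(=O)/N=C(/CCNC2=CC(=O)c3ccccc3C2=O)Nc2ccc(Cl)cc2)cc1` 65400 nM
compound 2 `Cc1ccc(S(=O)(=O)/N=C(/CCNC2=CC(=O)c3ccccc3C2=O)Nc2ccc(F)c(F)c2)cc1` 55200 nM

Compound 2 has the lowest of the two numbers, with compound 1 nearest at a 1.2-fold lower number from compound 1 to compound 2 (0.07 log units; within the scatter). Compound 3 `COc1cc(N/C(CCNC2=CC(=O)c3ccccc3C2=O)=N\S(=O)(=O)c2ccc(C)cc2)cc(OC)c1OC` differs from compound 2 by 3,4,5-trimethoxyphenyl in place of 3,4-difluorophenyl on an amine nitrogen. Among the measured compounds shown here, the only measured step at this position, the change from compound 1 to compound 2, stayed within the scatter, and no measured step exchanges a halogenated phenyl for a methoxylated one. No step beyond the scatter is therefore expected in this assay, so the estimated step is a 1.0-fold lower number from compound 2 to compound 3 (0.00 log units; within the scatter). Compound 3 is expected to give 55000 nM, within 25000 nM to 120000 nM.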

Compound 3, half-maximal inhibitory concentration: 75800 nM
Compound 3: the middle estimate sits 1.4-fold (0.14 log units) below what was measured; the measured number falls inside the stated range.
By their numbers in this assay, from the lowest: compounds 2, 1 and 3 (each within the scatter of the next).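

In this assay a methoxylated ring on the amine nitrogen stands level with the halogenated ones: 3,4,5-trimethoxyphenyl gives a 1.4-fold higher number from compound 2 to compound 3 (0.14 log units; within the scatter) and a 1.2-fold higher number from compound 1 to compound 3 (0.06 log units; within the scatter), so exchanging halogens for methoxy groups, with more heavy atoms and added acceptors, stays within the scatter. All three aryl groups at this position now lie within the scatter of one another, and no order among them can be read. No supporting measurement speaks to the reason for this flat result. Open, as far as these compounds go, is whether a phenyl carrying an amine or a carboxylic acid on this nitrogen, or an alkyl chain in place of the ring, would move the number beyond the scatter.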